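Flipping a Ring Stereocentre in a Cytotoxicity Series

A few compounds are considered here, and "the series" means these few. Any claim that something is new, unique, unknown or untested is made for them only; others in the source may bear on it.

Four compounds built on a shared core are compared here. In an ADME assay on HELF cells (Homo sapiens) for cytotoxicity, with a stated time of 3 days (on this read-out lower numbers stand for higher toxicity in this test and higher numbers for lower toxicity in this test), compound 1 `C[C@H](NC(=O)[C@@]1(Cc2ccccc2)CCN1C(=O)OCc1ccccc1)C(=O)N(C)C` reaches only the assay's limit, > 100000 nM. Compound 2 `CC(C)[C@H](NC(=O)[C@@]1(Cc2ccccc2)CCN1C(=O)OCc1ccccc1)C(N)=O` gives 85000 nM in this assay. Among the measured compounds shown here, the single measured step, an at least 1.1-fold lower number from compound 1 to compound 2 (0.07 log units; that floor lies within the scatter), stays within the scatter. Compound 3 `C[C@H](NC(=O)[C@]1(Cc2ccccc2)CCN1C(=O)OCc1ccccc1)C(=O)NC1CCCCC1` also reaches only the assay's limit, > 100000 nM, sitting at the limit of > 100000 nM in this assay, at which 2 of the 3 values shown sit. Compound 4 `C[C@H](NC(=O)[C@@]1(Cc2ccccc2)CCN1C(=O)OCc1ccccc1)C(=O)NC1CCCCC1` differs from compound 3 in configuration alone: the two compounds have the same atoms and bonds and differ only in configuration as drawn: 1 of 2 stereo elements differ; a stereocentre at a saturated ring carbon is drawn S in compound 3 and R in compound 4. For the measured compounds named here, no measured step covers such a change of configuration, and the one step that was measured, an at least 1.1-fold lower number from compound 1 to compound 2 (0.07 log units; that floor lies within the scatter), lies within the scatter. Compound 4 is therefore expected to show no step beyond the scatter, a number no higher from compound 3 to compound 4 (the limit leaves the size open), with an estimated value of 100000 nM, ranging from 50000 nM to 200000 nM.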

Compound 4, half-maximal cytotoxic concentration: 46000 nM
Compound 4: the middle estimate sits 2.2-fold (0.34 log units) above what was measured; measured number outside the range, below it.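

In this assay the configuration at this ring carbon matters: drawing it R rather than S gives an at least 2.1-fold lower number from compound 3 to compound 4 (0.33 log units; beyond the scatter), and nothing else changes: the fact that compounds 3 and 4 differ only in the configuration as drawn. On the R form, cyclohexylamino in place of dimethylamino gives an at least 2.1-fold lower number from compound 1 to compound 4 (0.33 log units; beyond the scatter), while 1-(cyclohexylcarbamoyl)ethyl in place of 1-carbamoyl-2-methylpropyl gives a 1.8-fold lower number from compound 2 to compound 4 (0.27 log units; within the scatter). Two of these steps start from a limit, so their full size is unknown: the limit of > 100000 nM in this assay, at which 2 of the 4 values shown sit.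

As far as these compounds go, it remains open whether the S form would also differ from the R form with dimethylamino on the carbonyl carbon. How a carboxylic acid or a longer chain in place of cyclohexylamino would read is open too.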